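Swapping a cyclopentyl for an isopropoxymethyl side chain

This account rests on a few compounds, and the source may have more. Where it says the series, first, only, none or still open, it means among the compounds named here.

Compound 2 `Nc1ccc2cccc(OCC3CCCC3)c2n1` gives 53 nM in an assay on cells with melanin-concentrating hormone receptor 1 (Homo sapiens) as the target, read by radioligand binding (a higher number here means a weaker inhibitor, a lower number a stronger inhibitor), the lowest of the two numbers reported. Compound 1 `CC(COC(C)(C)C)Oc1cccc2ccc(N)nc12` gives 306 nM in this assay, a gap beyond the usual scatter. Compound 3 `CC(CC(C)(C)C)Oc1cccc2ccc(N3CCCCC3)nc12` gives > 2000 nM in this assay, which is the limit of > 2000 nM in this assay, at which 1 of the 3 values shown sits, and not a number. The unmeasured compound 4 `CC(C)OCCOc1cccc2ccc(N)nc12` differs from compound 2 in one place: isopropoxymethyl in place of cyclopentyl on a saturated chain carbon bound to an oxygen on an aromatic ring. Within the data shown here, no measured pair covers this change, but compound 1, whose side chain likewise holds an ether oxygen, gives 306 nM, so a moderate move toward a weaker inhibitor is expected. Compound 4 is estimated at 200 nM in this assay, within 60 nM to 700 nM. The expected shift is a 3.8-fold higher number from compound 2 to compound 4 (0.58 log units; beyond the scatter).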

Compound 4, half-maximal inhibitory concentration: > 2000 nM
Compound 4 gave a limit, no number (the forecaster's own chance of this, stated with the estimate: 5%); middle value at least 10-fold (1.00 log units) from the limit.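

In this assay compound 4 gives > 2000 nM, a limit of the assay and not a number: the limit of > 2000 nM in this assay, at which 2 of the 4 values shown sit. Even so, the change of cyclopentyl to isopropoxymethyl on a saturated chain carbon bound to an oxygen on an aromatic ring gives an at least 37-fold higher number from compound 2 to compound 4 (1.57 log units; beyond the scatter), so this place responds strongly to a swap that leaves the heavy-atom count unchanged.

This single change removes the ring and brings in the ether oxygen together, and the compounds shown do not separate the two. A tetrahydrofuranyl ring or an open all-carbon chain such as isopentyl in this place would bear on that question.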